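This account rests on a few compounds, and the source may have more. Where it says the series, first, only, none or still open, it means among the compounds named here.

In a functional assay on MCF7 cells (Homo sapiens) for cytotoxicity, read by MTT assay, with a stated time of 48 h (a higher number here means a weaker inhibitor, a lower number a stronger inhibitor), compound 1 `C/C(=N\NC(=S)Nc1ccccc1)c1ccccn1` gives 0.18 nM, compound 2 `C/C(=N\NC(=S)Nc1ccc(F)cc1)c1ccccn1` gives 1.2 nM and compound 3 `C/C(=N\NC(=S)Nc1ccc([N+](=O)[O-])cc1)c1ccccn1` gives 52 nM. Compound 2 therefore holds the second highest of the three numbers, flanked by a 6.7-fold higher number from compound 1 to compound 2 (0.82 log units; beyond the scatter) and a 43-fold higher number from compound 2 to compound 3 (1.64 log units; beyond the scatter). The widest gap is a 290-fold higher number from compound 1 to compound 3 (2.46 log units; beyond the scatter). Compound 4 `CC(=NNC(=S)Nc1ccc(F)cc1)c1ccccn1` has the same atoms and bonds as compound 2, and the difference is the two compounds have the same atoms and bonds; at least one stereo element is drawn with a configuration in one of them and without one in the other: 1 of 1 stereo elements differ; a double bond is drawn E in compound 2 and without a configuration in compound 4. The measured steps all concern groups on an aromatic carbon, so none of them measures a change of this kind, however large they are. No shift beyond the scatter is expected in this assay, and the expected step is no change at the digits printed from compound 2 to compound 4 (within the scatter). Compound 4 is estimated at 1.2 nM, with an expected range of 0.5 nM to 3.2 nM.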

Compound 4, half-maximal inhibitory concentration: 1.2 nM
Beside the measured number, compound 4's estimate shows no gap at the digits printed; measured number inside the range.
By their numbers in this assay, from the lowest: compound 1; then compounds 2 and 4 (each within the scatter of the next); then compound 3.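

In this assay, removing the drawn E configuration of the double bond gives no change at the digits printed from compound 2 to compound 4 (within the scatter), the only step shown that stays within the scatter. The fluoro group on an aromatic carbon and the rest of the structure are untouched, so the earlier steps, all on aromatic substituents, could not have shown this. The two compounds are separated by the drawing alone: the fact that one of compounds 2 and 4 is drawn with a defined configuration and the other without, at the place where they differ

On these data alone, it remains open how a double bond drawn Z would read. Also open, as far as these compounds go, is where an analogue of compound 2 carrying an amine or a methoxy group instead of its fluoro would fall.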